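A few compounds are considered here, and "the series" means these few. Any claim that something is new, unique, unknown or untested is made for them only; others in the source may bear on it.

In an ADME assay on Vero cells (Chlorocebus sabaeus) for cytotoxicity, read by MTT assay, with a stated time of 48 h (a higher number here means a weaker inhibitor, a lower number a stronger inhibitor), compound 1 `Cc1cccc(C(=O)OC2CCC(CN3CCN(c4cc(=O)c5cc(C(F)(F)F)cc([N+](=O)[O-])c5s4)CC3)CC2)c1` gives > 64 ug/mL, which is a limit of the assay and not a number. Compound 2 `O=c1cc(N2CCN(CC3CCC(OS(=O)(=O)c4ccccc4)CC3)CC2)sc2c([N+](=O)[O-])cc(C(F)(F)F)cc12` gives > 64 ug/mL, and this too is a limit. Within the data shown here, compound 2 therefore stands at the same limit as the only other compound measured, and the limit of > 64 ug/mL in this assay, at which 2 of the 2 values shown sit, is all the evidence there is so far.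

Compound 3 `O=C(OC1CCC(CN2CCN(c3cc(=O)c4cc(C(F)(F)F)cc([N+](=O)[O-])c4s3)CC2)CC1)c1ccc2ccccc2c1` keeps the shared core and changes one group: (naphthalen-2-yl)carbonyl in place of phenylsulfonyl on an oxygen on a saturated carbon. Here (naphthalen-2-yl)carbonyl takes the place of phenylsulfonyl on an oxygen on a saturated carbon.

Among the measured compounds shown here, only one measured step bears on this change, because it falls at the same place: a step that the two limits leave unreadable from compound 1 to compound 2. Its size cannot be read, so it offers no number to carry forward. What it does show is that changing the group at this oxygen left the result at the limit. No step beyond the usual scatter is therefore expected in this assay, and no direction can be called. The expected change is a step that the limit leaves unreadable from compound 2 to compound 3. For compound 3 the estimated value is 80 ug/mL, with an expected range from 32 ug/mL to 160 ug/mL.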

Compound 3, half-maximal inhibitory concentration: > 64 ug/mL
Compound 3 gave a limit, no number (the forecaster's own chance of this, stated with the estimate: 85%); the middle value is on the limit's open side.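

In this assay compound 3 gives a limit and not a number, as do compound 1 and compound 2, so no step among these three compounds can be read. Going by these compounds, what stays open is how far each compound lies beyond the limit, and whether any group on this oxygen would give a measurable value in this assay at all.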